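Replacing the nitrile at the exocyclic alkene

This account rests on a few compounds, and the source may have more. Where it says the series, first, only, none or still open, it means among the compounds named here.

Measured compounds:
compound 1 `C/N=C(/S)C1(c2cccnc2)CCCC/C1=C\C#N` — 10000 nM
compound 2 `C/N=C(/S)C1(c2cccnc2)CCCC/C1=C\C=N\OCC(O)CO` — 3000 nM

Among the compounds with values here, in a functional assay (aorta) with Rattus norvegicus as the target (a lower number here means a stronger inhibitor, a higher number a weaker inhibitor), compound 1 gives 10000 nM, the highest of the two numbers; in the same assay compound 2 gives 3000 nM, and the only known step is a 3.3-fold lower number from compound 1 to compound 2 (0.52 log units; beyond the scatter), where the cyano group was exchanged for a larger chain. Compound 3 `C/N=C(/S)C1(c2cccnc2)CCCC/C1=C\COc1ccccc1` shares the core of compound 1 and differs from it in one place: phenoxymethyl in place of cyano on a double-bonded chain carbon bound to a double-bonded ring carbon. Within the data shown here, the change in compound 3 is of similar size to the one that produced compound 2, but the entering group carries a six-membered aromatic ring instead of a chain with hydroxyls, so only the direction, not the magnitude, can be taken from that single step. Compound 3 is therefore expected to show a modest lowering, a 2.5-fold lower number from compound 1 to compound 3 (0.40 log units; beyond the scatter). The estimate for compound 3 is 4000 nM, with a range from 1500 nM to 15000 nM.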

Compound 3, concentration for 90% inhibition: 65 nM
Estimate against measurement, compound 3: 62-fold (1.79 log units) above; the whole stated range lies above it.
By their numbers in this assay, from the lowest: compound 3; then compound 2; then compound 1.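

In this assay, this position proves far more sensitive than the first step suggested: phenoxymethyl in place of cyano, on a double-bonded chain carbon bound to a double-bonded ring carbon, brings a 150-fold lower number from compound 1 to compound 3 (2.19 log units; beyond the scatter) for the shared core. The groups entering in compound 2 and compound 3 have the same count of heavy atoms, yet the exchange gives a 46-fold lower number from compound 2 to compound 3 (1.66 log units; beyond the scatter) in this assay, so heavy-atom count alone does not fix the number here, and the six-membered aromatic ring of carbon only goes with the much lower value. No measurement shown accounts for this gain.

Going by these compounds, whether the gain rests on the aromatic ring or on the oxygen that joins it to the chain stays open. A plain phenyl group and a cyclohexyloxymethyl group at this place would separate the two.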